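Series notes: from compound 3 to compound 4

The source may hold more compounds than are shown below. What is called first, only, known or untested is meant among the compounds shown, and "the series" means these compounds.

Of the compounds shown here, three have been measured in a functional assay on KB cells (Homo sapiens) for cytotoxicity, read by sulforhodamine B assay; on this read-out higher numbers stand for weaker inhibition and lower numbers for stronger inhibition. Compound 1 `C=C1[C@@H](OC(C)=O)C[C@@H]2[C@](C)(CO[Si](C)(C)C(C)(C)C)[C@H](OC(C)=O)CC[C@@]2(C)[C@@H]1C[C@@H](Nc1ccccc1)C1=CCOC1=O` gives 5710 nM; compound 2 `C=C1[C@@H](C/C=C2/C(=O)OC[C@H]2OC(C)=O)[C@]2(C)CC[C@@H](OC(C)=O)[C@@](C)(CO[Si](C)(C)C(C)(C)C)[C@H]2C[C@@H]1O` gives 9790 nM; compound 3 `C=C1[C@@H](OC(C)=O)C[C@@H]2[C@](C)(COC=O)[C@H](OC(C)=O)CC[C@@]2(C)[C@@H]1C[C@@H](Nc1ccc(Br)cc1)C1=CCOC1=O` gives 24000 nM. Compound 3 thus stands at the highest of the three numbers and is the weakest inhibitor so far: its nearest neighbour is compound 2, whose number is lower by a margin beyond the scatter, and compound 1 lies further below, also beyond the scatter.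

Compound 4 `C=C1[C@@H](OC(C)=O)C[C@@H]2[C@](C)(COC=O)[C@H](OC(C)=O)CC[C@@]2(C)[C@@H]1C[C@@H](Nc1ccc(OC)c(OC)c1)C1=CCOC1=O` differs from compound 3 in one place: 3,4-dimethoxyphenyl in place of 4-bromophenyl on an amine nitrogen. Elsewhere the two structures are identical.

For the measured compounds named here, no step between two measured compounds isolates a change of this kind. Compound 1 carries a different group on the amine nitrogen and gives 5710 nM, well below compound 3, so the group on that nitrogen does move the number, but with only these two points the direction for the dimethoxyphenyl cannot be read off. The step of a 1.6-fold lower number from compound 3 to compound 4 (0.20 log units; within the scatter) is therefore expected to be modest and of uncertain direction, and the range is set wide to reflect this. Compound 4 is estimated at 15000 nM, between 4000 nM and 60000 nM.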

Compound 4, half-maximal inhibitory concentration: > 50000 nM
Compound 4: no number, only a limit (the forecaster's own chance of this, stated with the estimate: 10%); middle value at least 3.3-fold (0.52 log units) from the limit.
By their numbers in this assay, from the lowest: compounds 1 and 2 (each within the scatter of the next); then compound 3. At a limit, above all of these: compound 4.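

In this assay compound 4 gives no number, only a limit of the assay, > 50000 nM. Even so, replacing 4-bromophenyl with 3,4-dimethoxyphenyl on an amine nitrogen whose other neighbour is a saturated chain carbon gives an at least 2.0-fold higher number from compound 3 to compound 4 (0.31 log units; beyond the scatter), the first step in the series that isolates this position and shows that the number responds to the aromatic group there, with the change going towards weaker inhibition. On these data alone, the step has only a lower bound, and its full size stays unknown, since the value of compound 4 rests on a limit: the limit of > 50000 nM in this assay, at which 1 of the 4 values shown sits.

For the compounds shown here, this single pair cannot separate the removal of the bromine from the entry of the two methoxy groups, and compound 1 differs from compound 3 in more than one place, so it adds no second step at this nitrogen. A phenyl ring bearing a single methoxy group or a chlorine, or a pyridine ring or a simple alkyl chain on the same nitrogen, would show whether the trend holds and how far this position tolerates change.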